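Chloro removal on a shared core, two benzyl pairs

The source may report more compounds than this note shows. Statements on the series, on what has been measured and on what is new or still open speak of the compounds shown alone.

Measured so far, in a functional assay on UACC-257 cells (Homo sapiens) for cytotoxicity, read by sulforhodamine B assay, with a stated time of 48 h; on this read-out higher numbers stand for weaker inhibition of growth and lower numbers for stronger inhibition of growth:
- compound 1 `ClCc1ccccc1Cn1cnc2c(Cl)nc(Cl)nc21` gives 3890 nM
- compound 2 `ClCc1ccccc1Cn1cnc2c(Cl)ncnc21` gives 26300 nM
- compound 3 `ClCc1ccc(Cn2cnc3nc(Cl)nc(Cl)c32)cc1` gives 5490 nM

Compound 1 and compound 2 form a matched pair. The change is hydrogen in place of chloro on an aromatic carbon, and in this assay the step is a 6.8-fold higher number from compound 1 to compound 2 (0.83 log units; beyond the scatter).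

Compound 3 is built from the same atoms as compound 1, joined differently; the difference between the two cores is not broken down here. The values of compound 3 and compound 1 in this assay lie within the scatter of each other, so no order between them is read.

Compound 4 `ClCc1ccc(Cn2cnc3ncnc(Cl)c32)cc1` has not been measured in this assay. It differs from compound 3 by hydrogen in place of chloro on an aromatic carbon. This is the same change as that from compound 1 to compound 2, and it occurs twice among the four compounds, with the surroundings of the place described in identical words for both pairs. Within the data shown here, the only precedent for the change on this core is the modest step from compound 1 to compound 2.

Among the measured compounds shown here, for compound 4 the expected step is a 6.4-fold higher number from compound 3 to compound 4 (0.80 log units; beyond the scatter), because a 6.8-fold higher number from compound 1 to compound 2 (0.83 log units; beyond the scatter) is the sole measured instance of this change and is taken as the guide. Compound 4 is therefore estimated at 35000 nM in this assay. For compound 4 the expected range runs from 12000 nM to 100000 nM, the width reflecting that one precedent alone supports it.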

Compound 4, concentration for total growth inhibition: 3460 nM
Estimate against measurement, compound 4: 10-fold (1.00 log units) above; the whole stated range lies above it.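

On the second core, hydrogen in place of chloro on an aromatic carbon gives a 1.6-fold lower number from compound 3 to compound 4 (0.20 log units; within the scatter), so in this assay no order is read between the two compounds of this pair. The step seen on one core therefore does not carry over to the other in this series, since the two steps differ by more than the scatter allows: the same change on two cores in this assay, a 6.8-fold higher number (0.83 log units; beyond the scatter) from compound 1 to compound 2 and a 1.6-fold lower number (0.20 log units; within the scatter) from compound 3 to compound 4, 11-fold (1.03 log units) apart, beyond the scatter of two such steps. This shows that, across these two pairs, the outcome of the change depends on the core; it does not show which difference between the cores is responsible, and two pairs give no rule for a further core.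

Going by these compounds, all four compounds keep a chloromethyl group on the benzyl ring and a chloro group on the fused ring system, so it remains open whether the difference between the cores persists when the chloromethyl group gives way to a hydroxymethyl group or the remaining chloro group to an amine. Also open is whether the same contrast between the two pairs appears in cell lines other than the one shown here, as every value above comes from a single cell line.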